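The source may report more compounds than this note shows. Statements on the series, on what has been measured and on what is new or still open speak of the compounds shown alone.

In an in vitro ADME assay on microsomes from liver (Homo sapiens) for metabolic stability, read by LC-MS, tested at 1 uM (on this read-out higher numbers stand for fast clearance and lower numbers for slow clearance), compound 3 `Cc1ccc(S(=O)(=O)N2CCOCC2)cc1C#Cc1cc(Cl)ccc1OCC(=O)O` gives < 10 mL.min-1.g-1, which is a limit and not a number. Compound 2 `Cc1ccc(S(=O)(=O)NC(C)C)cc1C#Cc1cc(Cl)ccc1OCC(=O)O` gives < 10 mL.min-1.g-1, also a limit. For the measured compounds named here, compound 1 `COCCN(C)S(=O)(=O)c1ccc(C)c(C#Cc2cc(Cl)ccc2OCC(=O)O)c1` gives 32 mL.min-1.g-1, the only true number so far. Compound 4 `Cc1ccc(S(=O)(=O)N(C)C)cc1C#Cc1cc(Cl)ccc1OCC(=O)O` remains unmeasured and differs from compound 3 by dimethylamino in place of morpholin-4-yl on a sulfonyl sulfur. Two measured changes at that sulfur bear on this, an at least 3.2-fold lower number from compound 1 to compound 2 (0.50 log units; beyond the scatter) and an at least 3.2-fold lower number from compound 1 to compound 3 (0.50 log units; beyond the scatter), so this group can shift the read-out. Neither step involves dimethylamino, so only a small upward move in this assay is expected, possibly none beyond the scatter. The expected change is an at least 1.1-fold higher number from compound 3 to compound 4 (0.04 log units; that floor lies within the scatter). For compound 4 the estimate is 11 mL.min-1.g-1, with an expected range from 5 mL.min-1.g-1 to 25 mL.min-1.g-1.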

Compound 4, intrinsic clearance in microsomes: < 10 mL.min-1.g-1
Compound 4: only a limit was reported (the forecaster's own chance of this, stated with the estimate: 50%); middle value at least 1.1-fold (0.04 log units) away from the limit.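

In this assay compound 4 gives < 10 mL.min-1.g-1, again a limit and not a number. Hydrogen in place of methoxymethyl on the chain of compound 1 gives an at least 3.2-fold lower number from compound 1 to compound 4 (0.50 log units; beyond the scatter), so a third group on the sulfonyl sulfur, dimethylamino, which has no ring, also falls short of the number seen for compound 1. The steps among compound 2, compound 3 and compound 4 cannot be read, as all three stop at one floor: the limit of < 10 mL.min-1.g-1 in this assay, at which 3 of the 4 values shown sit.

On these data alone, how far under that limit these compounds lie stays open. Also open, as far as these compounds go, is whether piperidin-1-yl or a longer plain carbon chain on the sulfonamide nitrogen would give a true number.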